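The source may hold more compounds than are shown below. What is called first, only, known or untested is meant among the compounds shown, and "the series" means these compounds.

Measured compounds in this series:

Compound 1, `N/N=C/c1cc2ccccc2[nH]c1=O`: 365000 nM
Compound 2, `O=c1[nH]c2ccccc2cc1/C=N/Nc1ccc([N+](=O)[O-])cc1`: 245000 nM
Compound 3, `Cc1ccc2[nH]c(=O)c(/C=N/Nc3ccccc3)cc2c1`: 1470000 nM

All three were run in a functional assay, read by spectrophotometry, with a stated time of 1 h; a higher number here means a weaker inhibitor, a lower number a stronger inhibitor. Compound 3 stands highest of the three numbers in this assay, with compound 1 the nearest and compound 2 the furthest; both gaps lie beyond the usual scatter, so compound 3 is the weakest inhibitor among the measured set. Compound 1 and compound 2 are within the scatter of each other and are not ranked against one another.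

Compound 4, `O=c1[nH]c2ccccc2cc1/C=N/Nc1ccccc1`, is not yet measured. It differs from compound 3 in one place: hydrogen in place of methyl on an aromatic carbon. Compound 4 thus carries the same unsubstituted core as compound 1 and compound 2, with the phenylhydrazone of compound 3. Among the measured compounds shown here, no directly comparable pair of measured compounds shows what this change does in this assay. The expectation is a modest step downward from compound 3 to compound 4, a 2.7-fold lower number from compound 3 to compound 4 (0.43 log units; beyond the scatter), bringing compound 4 nearer to the values of compound 1 and compound 2, though the step might also fall within the scatter. Compound 4 is estimated at 550000 nM, with a range from 200000 nM to 1500000 nM.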

Compound 4, half-maximal inhibitory concentration: 1000000 nM
The estimate for compound 4 lay 1.8-fold (0.26 log units) below the measured number; the measured number falls inside the stated range.
By their numbers in this assay, from the lowest: compounds 2 and 1 (each within the scatter of the next); then compounds 4 and 3 (each within the scatter of the next).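

Methyl on this aromatic carbon of the shared core, meta to a fused ring and para to a fused ring, gives no readable change in this assay: hydrogen in its place gives a 1.5-fold lower number from compound 3 to compound 4 (0.17 log units; within the scatter), so this position, tested with these two groups alone, does not separate the phenyl compounds. The readable differences lie elsewhere, with removal of the nitro group giving a 4.1-fold higher number from compound 2 to compound 4 (0.61 log units; beyond the scatter) and phenyl in place of hydrogen on the amine nitrogen giving a 2.7-fold higher number from compound 1 to compound 4 (0.44 log units; beyond the scatter), both in the direction of a weaker inhibitor at compound 4. No accompanying data bear on the origin of any of these steps.

On these data alone, whether a methoxy group or a carboxylic acid on the core carbon that carries methyl in compound 3 would give a step beyond the scatter remains open. Also open, as far as these compounds go, are whether an amine in place of nitro gives a step of similar size, and whether the methyl step stays within the scatter when nitro is present.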